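Dropping the Chlorine from Compound 1

A few compounds are considered here, and "the series" means these few. Any claim that something is new, unique, unknown or untested is made for them only; others in the source may bear on it.

Measured so far:
- compound 1, `Nc1ccccc1NC(=O)/C=C/c1ccc(COCNc2nc(Nc3cccc(Cl)c3)c3ncn(C4CCCC4)c3n2)cc1`: 9.04%
- compound 2, `CC(C)n1cnc2c(Nc3cccc(Cl)c3)nc(NCOCc3ccc(/C=C/C(=O)Nc4ccccc4N)cc3)nc21`: 18.5%
- compound 3, `Nc1ccccc1NC(=O)c1ccc(COCNc2nc(Nc3cccc(Cl)c3)c3ncn(C4CCCC4)c3n2)cc1`: 29.2%

These three compounds were tested in a functional assay on HCT-116 cells (Homo sapiens) for antiproliferative activity, read by CCK-8 assay, with a stated time of 72 h, tested at 2 uM; a lower number here means a weaker effect, a higher number a stronger effect of the compound at the concentration tested. Compound 1 gives the lowest of the three numbers. Its nearest neighbour is compound 2, where the change is a number 9.5 percentage points higher from compound 1 to compound 2 (within the scatter). The step to compound 3 is larger: a number 20.2 percentage points higher from compound 1 to compound 3 (beyond the scatter).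

Compound 4 is `Nc1ccccc1NC(=O)/C=C/c1ccc(COCNc2nc(Nc3ccccc3)c3ncn(C4CCCC4)c3n2)cc1`. It differs from compound 1 in one place: hydrogen in place of chloro on an aromatic carbon.

Neither measured step touches this part of the molecule. The step to compound 2 changes the group on an aromatic nitrogen, the step to compound 3 changes the linker to the (2-aminophenyl)carbamoyl end; the chlorine stays untouched in both. So no measured step bears directly on the change from compound 1 to compound 4, and the expectation can only be that a single chloro removed on a ring far from both measured changes produces no step beyond the scatter in this assay. The estimated step is a number 1 percentage points lower from compound 1 to compound 4 (within the scatter). Compound 4 is expected to give about 8%, within a range from 0% to 24%.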

Compound 4, a percentage reported as inhibition, at one concentration (the size of the read-out at that concentration, not a potency): 10.5%
The estimate for compound 4 lay 2.5 percentage points below the measured number; the measured number falls inside the stated range.
By their numbers in this assay, from the lowest: compounds 1, 4 and 2 (each within the scatter of the next); then compound 3.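

In this assay, the step for replacing the chloro with hydrogen on the anilino ring is a number 1.5 percentage points higher from compound 1 to compound 4 (within the scatter), so the change from 3-chlorophenyl to phenyl cannot be told apart from the usual scatter. Among the compounds shown here, this is the first direct reading at this position, and it shows that, in the setting of compound 1, the chlorine is not needed to keep the effect at the level seen at this single concentration. Nothing measured here explains this result.

Other groups on this ring, such as a methoxy group, an amine or a carboxylic acid, remain open, and so does the effect of other places on the ring. On these data alone, it is also open whether removing the chloro from compound 3, which has a higher number than compound 1, would give a similarly small step.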